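A few compounds are considered here, and "the series" means these few. Any claim that something is new, unique, unknown or untested is made for them only; others in the source may bear on it.

The compounds measured so far, all in a functional assay on ACHN cells (Homo sapiens) for antiproliferative activity, read by sulforhodamine B assay; a lower number here means a stronger inhibitor of growth, a higher number a weaker inhibitor of growth:
compound 1, `O=c1[nH]c(=O)n([C@H]2C[C@H](O)[C@@H](CO)O2)cc1-c1cn(CCC(F)(F)C(F)(F)C(F)(F)C(F)(F)F)nn1`, gives 116 uM
compound 2, `O=c1[nH]c(=O)n([C@H]2C[C@H](O)[C@@H](CO)O2)cc1-c1cn(CCC(F)(F)C(F)(F)C(F)(F)C(F)(F)C(F)(F)C(F)(F)C(F)(F)C(F)(F)C(F)(F)C(F)(F)F)nn1`, gives 90.8 uM
compound 3, `O=c1[nH]c(=O)n([C@H]2C[C@H](O)[C@@H](CO)O2)cc1-c1cn(CCC(F)(F)C(F)(F)C(F)(F)C(F)(F)C(F)(F)C(F)(F)F)nn1`, gives 99.3 uM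

All three share the same core and differ only in the fluorinated chain attached to it. On these numbers compound 3 stands second highest of three; its nearest neighbour is compound 2 and its furthest is compound 1, yet both gaps are within the scatter, so the three compounds cannot be told apart in this assay.

Compound 4, `O=c1[nH]c(=O)n([C@H]2C[C@H](O)[C@@H](CO)O2)cc1-c1cn(CCC(F)(F)C(F)(F)C(F)(F)C(F)(F)C(F)(F)C(F)(F)C(F)(F)C(F)(F)F)nn1`, is not yet measured. It differs from compound 3 in one place: 1,1,2,2,2-pentafluoroethyl in place of fluoro on a saturated chain carbon bound to two fluorine atoms and a saturated chain carbon. The same kind of change has already been seen once, from compound 1 to compound 3, which gave a 1.2-fold lower number from compound 1 to compound 3 (0.07 log units; within the scatter). Compound 2 and compound 3, which also differ only in that chain, give values lying within the scatter of each other. Going by the values given here, nothing among the measured compounds points to a step beyond the scatter, so compound 4 is expected to give about the same number as compound 3, with a 1.0-fold lower number from compound 3 to compound 4 (0.02 log units; within the scatter) as the estimated step. The estimate for compound 4 is 95 uM, expected to fall between 60 uM and 150 uM.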

Compound 4, concentration for growth inhibition (reported as GI): 14.2 uM
For compound 4 the middle estimate is 6.7-fold (0.83 log units) above the measured one; the whole stated range lies above it.
By their numbers in this assay, from the lowest: compound 4; then compounds 2, 3 and 1 (each within the scatter of the next).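

In this assay, going by these compounds alone, putting 1,1,2,2,2-pentafluoroethyl in place of fluoro on a saturated chain carbon bound to two fluorine atoms and a saturated chain carbon is not the silent change that the earlier compounds suggested, giving a 7.0-fold lower number from compound 3 to compound 4 (0.84 log units; beyond the scatter). Going the other way, fluoro in place of 1,1,2,2,2-pentafluoroethyl at this kind of carbon gives a 6.4-fold lower number from compound 2 to compound 4 (0.81 log units; beyond the scatter), so the number does not simply keep falling as the chain grows: compound 4 stands apart from both compounds that lie one such change away from it, while compound 2 and compound 3 remain within the scatter of each other. The same change therefore has an effect that depends on the chain it is made on: the same change on two cores in this assay, a 1.2-fold lower number (0.07 log units; within the scatter) from compound 1 to compound 3 and a 6.4-fold higher number (0.81 log units; beyond the scatter) from compound 4 to compound 2, 7.5-fold (0.87 log units) apart, beyond the scatter of two such steps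

The compounds shown leave open whether the lower number in compound 4 depends on the fluorine atoms of its chain or on the length of the chain alone, a question that a plain hydrocarbon chain of the same length would address. They also leave open whether this chain would tolerate an end group such as an amine or a carboxylic acid in place of its final trifluoromethyl.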